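Working notes: the step from compound 2 to compound 4

The source may report more compounds than this note shows. Statements on the series, on what has been measured and on what is new or still open speak of the compounds shown alone.

In an assay on isolated protein for binding affinity to corticotropin-releasing factor receptor 1 (Homo sapiens) (a lower number here means a stronger inhibitor, a higher number a weaker inhibitor), compound 1 `C=CCN(CC=C)c1nc(C)nc(Nc2c(C)cc(C)cc2C)n1` gives 115 nM. Compound 3 `C=CCN(CC=C)c1nc(C)nc(Nc2c(CC)cccc2CC)n1` gives 5700 nM in this assay. Compound 2 `CCCN(Cc1ccccc1)c1nc(C)nc(Nc2ccc(C)cc2)n1` gives only > 10000 nM in this assay, a limit of the assay rather than a number, namely (the limit of > 10000 nM in this assay, at which 1 of the 3 values shown sits). Compound 2 thus sits at the weak end of the values shown. Compound 4 `CCCN(Cc1ccccc1)c1nc(C)nc(Nc2c(C)cccc2C)n1` is not yet measured; it differs from compound 2 by 2,6-dimethylphenyl in place of 4-methylphenyl on a nitrogen on an aromatic ring. For the measured compounds named here, no measured step covers this change. Compounds 1 and 3 both carry 2,6-disubstitution and give numbers rather than limits, so a step toward stronger binding is expected, an at least 6.6-fold lower number from compound 2 to compound 4 (0.82 log units; beyond the scatter). Compound 4 is estimated at 1500 nM, with a range of 200 nM to 10000 nM.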

Compound 4, inhibition constant: > 10000 nM
Compound 4: no number, only a limit; the forecaster's own chance of this, stated with the estimate: 25%; middle value at least 6.6-fold (0.82 log units) away from the limit.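

In this assay, for the compounds shown here, compound 2 and compound 4 both give only a limit, not a number, so no step between them can be read. Left open is whether 2,6-dimethylphenyl in place of 4-methylphenyl changes binding at all.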